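Changing the Ester Group of Compound 2

A few compounds are considered here, and "the series" means these few. Any claim that something is new, unique, unknown or untested is made for them only; others in the source may bear on it.

Compound 1 `COc1cc(/C=C/c2ccc(C3=C(c4ccc(O)cc4)C4CC(S(=O)(=O)Oc5ccc(Br)cc5)C3O4)cc2)cc(OC)c1` reaches only a limit of the assay, > 100000 nM, in a functional assay on MCF7 cells (Homo sapiens) for antiproliferative activity, read by MTT assay, with a stated time of 72 h; a lower number here means a stronger inhibitor, a higher number a weaker inhibitor. Among the compounds with values here, compound 2 `O=S(=O)(Oc1ccccc1Cl)C1CC2OC1C(c1ccc(/C=C/c3cc(O)cc(O)c3)cc1)=C2c1ccc(O)cc1` is the one compound with an actual number, giving 40400 nM in this assay. Compound 3 `Cc1ccc(OS(=O)(=O)C2CC3OC2C(c2ccc(/C=C/c4cc(O)cc(O)c4)cc2)=C3c2ccc(O)cc2)cc1` differs from compound 2 by 4-methylphenyl in place of 2-chlorophenyl on an oxygen. No change of this kind has been measured here, so the step from compound 2 to compound 3 is expected to stay within the usual scatter, with no clear direction. Compound 3 is therefore expected to give about 40000 nM in this assay, between 15000 nM and 100000 nM. The expected step is a 1.0-fold lower number from compound 2 to compound 3 (0.00 log units; within the scatter).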

Compound 3, half-maximal inhibitory concentration: 9200 nM
Compound 3: the middle estimate sits 4.3-fold (0.64 log units) above what was measured, and the stated range ends above it.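

In this assay, 4-methylphenyl in place of 2-chlorophenyl on the oxygen bound to the sulfonyl sulfur gives a 4.4-fold lower number from compound 2 to compound 3 (0.64 log units; beyond the scatter), which shows that the number responds to the aryl group at this position. Within the data shown here, the single step changes chloro to methyl and 2- to 4-substitution together, so the two cannot be told apart. Compound 1 gives no further reading of this position: the limit of > 100000 nM in this assay, at which 1 of the 3 values shown sits.

On these data alone, whether 4-chlorophenyl or 2-methylphenyl would separate these two changes stays open. So does the outcome with unsubstituted phenyl or an ethyl chain on that oxygen.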